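The source may report more compounds than this note shows. Statements on the series, on what has been measured and on what is new or still open speak of the compounds shown alone.

In an ADME assay on MT4 cells (Homo sapiens) for cytotoxicity (a lower number here means that less compound is tolerated, a higher number that more compound is tolerated), compound 2 `Cc1cc(C)cc(S(=O)(=O)n2c(=O)[nH]c3ccc(Cl)cc32)c1` gives 39000 nM, and compound 3 `Cc1cc(C)cc(S(=O)(=O)n2c(=O)[nH]c3cc(F)c(Cl)cc32)c1` gives 140000 nM. The change between them is fluoro in place of hydrogen on an aromatic carbon, and that step, a 3.6-fold higher number from compound 2 to compound 3 (0.56 log units; beyond the scatter), left more compound tolerated. Compound 1 `O=c1[nH]c2ccc(Cl)cc2n1Cc1c(F)cccc1F` belongs to a different series; how its core differs from that of compound 2 is not broken down here. For compound 1 the limit of > 424000 nM in this assay, at which 1 of the 3 values shown sits, is a limit of the method rather than a measured number, so in this assay compound 1 gives > 424000 nM. Compound 4 `O=c1[nH]c2cc(F)c(Cl)cc2n1Cc1c(F)cccc1F` carries the same kind of change, (fluoro in place of hydrogen on an aromatic carbon), with the place described in the same words. Resting on the step from compound 2 to compound 3, the step that the limit leaves unreadable from compound 1 to compound 4 is expected to be small and again toward more tolerance. In this assay compound 4 is therefore estimated at 500000 nM, between 300000 nM and 1500000 nM.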

Compound 4, half-maximal cytotoxic concentration: 267000 nM
Compound 4: the middle estimate sits 1.9-fold (0.27 log units) above what was measured; the whole stated range lies above it.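

In this assay, fluoro in place of hydrogen on an aromatic carbon gave an at least 1.5-fold lower number from compound 1 to compound 4 (0.20 log units; that floor lies within the scatter). Set beside the same change on the other core, this shows that the step does not carry over unchanged between these two cores: the same change on two cores in this assay, a 3.6-fold higher number (0.56 log units; beyond the scatter) from compound 2 to compound 3 and an at least 1.5-fold lower number (0.20 log units; that floor lies within the scatter) from compound 1 to compound 4, at least 5.7-fold (0.75 log units) apart, beyond the scatter of two such steps. Compound 1 gives > 424000 nM, which is a limit and not a number, so the true size of its step stays unread, and two cores alone do not show how the change would behave on a third: the limit of > 424000 nM in this assay, at which 1 of the 4 values shown sits.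

The compounds shown leave open what a nitrile or a methoxy group at the same place would do on either core. They also leave open whether an amine there would follow either step.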